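Methyl in place of trifluoromethyl: compound 4

The compounds below may be only part of what the source reports. "The series", "measured", "known", "first", "only" and "open" are said of these compounds alone.

Compound 1 `O=S(=O)(Nc1ccc(-c2nc3ccccc3o2)cc1)c1ccc(C(F)(F)F)cc1` is one of three compounds examined in an assay on isolated protein for inhibition of malate dehydrogenase, mitochondrial (Sus scrofa), with stated times of 45 min and 30 min; on this read-out lower numbers stand for stronger inhibition and higher numbers for weaker inhibition. In this assay compound 1 gives > 63000 nM, which is a limit of the assay and not a number. Compound 2 `C=Cc1ccc(S(=O)(=O)Nc2ccc3oc(-c4ccccc4)nc3c2)cc1` gives > 63000 nM, again a limit. Compound 3 `O=S(=O)(Nc1ccc2oc(-c3ccccc3)nc2c1)c1cccc(O)c1` gives > 63000 nM, also a limit. Between the last two lies the step that the two limits leave unreadable from compound 2 to compound 3. Within the data shown here, all three values share (the limit of > 63000 nM in this assay, at which 3 of the 3 values shown sit), so no measured step carries a readable size. Compound 4 `Cc1ccc(S(=O)(=O)Nc2ccc(-c3nc4ccccc4o3)cc2)cc1` differs from compound 1 by methyl in place of trifluoromethyl on an aromatic carbon. Among the measured compounds shown here, no measured pair shows this change, and nothing beyond the scatter is expected in this assay; a further limit is the more probable outcome. The expected step is a step that the limit leaves unreadable from compound 1 to compound 4. Compound 4 is estimated at 80000 nM, within a range of 30000 nM to 200000 nM.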

Compound 4, half-maximal inhibitory concentration: > 63000 nM
Compound 4: no number, only a limit (the forecaster's own chance of this, stated with the estimate: 85%); the middle value does not contradict the limit.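

Compound 1 and compound 4 each give only a limit, so no new step can be read from this pair: the limit of > 63000 nM in this assay, at which 4 of the 4 values shown sit. The compounds shown leave open which structural change, if any, yields a readable number.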